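Swapping the amine arm on a sulfamate inhibitor scaffold

The source may report more compounds than this note shows. Statements on the series, on what has been measured and on what is new or still open speak of the compounds shown alone.

Measured compounds:
compound 1, `CCN(Cc1ccccn1)c1ccc(C(=O)N2CCc3ccc(OS(N)(=O)=O)cc3C2)cc1`, 42.5%
compound 2, `CN(C)CCN(Cc1ccccc1)c1cccc(C(=O)N2CCc3ccc(OS(N)(=O)=O)cc3C2)c1`, 0%
compound 3, `CCCN(Cc1ccccc1)c1cccc(C(=O)N2CCc3ccc(OS(N)(=O)=O)cc3C2)c1`, 23.1%

In an assay on HEK293 cells for inhibition of Steryl-sulfatase (Homo sapiens), tested at 0.1 uM (a higher number here means a stronger effect of the compound at the concentration tested, a lower number a weaker effect), compound 1 gives 42.5%, the highest of the three numbers; compound 3 sits beyond the scatter below it, and compound 2 is furthest away at the bottom. For the measured compounds named here, the only single-point step among the measured compounds is a number 23.1 percentage points higher from compound 2 to compound 3 (beyond the scatter), a modest gain tied to a change on the chain, not on the ring-bound arm.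

Compound 4 is `CCCN(Cc1ccccc1)c1ccc(C(=O)N2CCc3ccc(OS(N)(=O)=O)cc3C2)cc1`. It differs from compound 1 by benzyl(propyl)amino in place of ethyl((pyridin-2-yl)methyl)amino on an aromatic carbon. Going by the values given here, no measured step covers this exchange of one amine arm for another, so the expectation rests on what compound 1 and compound 3 show: compound 3 carries the same benzyl(propyl)amino group on a differently substituted core and gives a weaker value than compound 1. The step of a number 9.5 percentage points lower from compound 1 to compound 4 (within the scatter) is therefore expected to be a moderate decline, with wide uncertainty. Compound 4 is estimated at 33%, within 10% to 58%.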

Compound 4, a percentage reported as inhibition, at one concentration (the size of the read-out at that concentration, not a potency): 64.8%
For compound 4 the middle estimate is 31.8 percentage points below the measured one; the whole stated range lies below it.
By their numbers in this assay, from the lowest: compound 2; then compound 3; then compound 1; then compound 4.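

In this assay the exchange on this aromatic carbon, para to a large group, gives a number 22.3 percentage points higher from compound 1 to compound 4 (beyond the scatter) and so shows that the pyridine ring of the leaving arm is not required for a strong effect at the concentration tested. The two arms differ in two ways at once, a pyridine ring against a ring of carbon only and an ethyl against a propyl chain on the nitrogen, so this single step cannot say which difference carries the gain. No measurement at hand gives a reason for the rise.

An arm such as benzyl(ethyl)amino would separate the effect of the ring from that of the chain. On these data alone, whether a longer chain, such as butyl, on the same nitrogen raises the number further remains open.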